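Swapping a lactam ring for a small sulfur group

The source may report more compounds than this note shows. Statements on the series, on what has been measured and on what is new or still open speak of the compounds shown alone.

For the measured compounds named here, in an assay on CHO cells for agonist activity at Glucose-dependent insulinotropic receptor (Homo sapiens), read by a luciferase reporter and cAMP accumulation, with a stated time of 2 h (a higher number here means that more compound is needed for the effect, a lower number that less compound is needed), compound 1 `CC(C)c1noc(N2CCC(Oc3cc(N4CCc5cc(N6CCCCC6=O)ccc54)ncn3)CC2)n1` gives 17 nM, the only single number among the three measured compounds. Compound 2 `CC(C)SC(=O)N1CCC(Oc2cc(N3CCc4cc([S+]([O-])CCO)ccc43)ncn2)CC1` carries a different group on the other end of the shared core and in this assay gives 14 nM; 57 nM; 9.7 nM (3 entries), drawn from the several entries of compound 2 in this assay, 14 nM; 57 nM; 9.7 nM (3 entries). Compound 3 `CC(C)SC(=O)N1CCC(Oc2cc(N3CCc4ccccc43)ncn2)CC1`, which lacks any substituent on the fused carbon ring, reaches only the limit of this assay, > 10000 nM, so for it no number is known.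

Compound 4 `CC(C)c1noc(N2CCC(Oc3cc(N4CCc5cc([S+]([O-])CCO)ccc54)ncn3)CC2)n1` keeps the end of compound 1 and takes from compound 2 the group on the fused ring: a group of 5 heavy atoms (2 carbon, 2 oxygen, 1 sulfur; no ring) in place of a group of 7 heavy atoms (5 carbon, 1 nitrogen, 1 oxygen; one six-membered non-aromatic ring with 1 hetero atom), on an aromatic carbon Compound 2 keeps activity with this entering group in place, while compound 3, bare at that position, sits at the limit of > 10000 nM in this assay, at which 1 of the 3 values shown sits. The 2-oxopiperidin-1-yl group of compound 1 and the entering group both appear compatible with activity. No step beyond the usual scatter is expected; the change from compound 1 to compound 4 is estimated at a 1.1-fold lower number from compound 1 to compound 4 (0.05 log units; within the scatter). Compound 4 is therefore expected to give about 15 nM, within the range 5 nM to 50 nM.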

Compound 4, half-maximal effective concentration: 48 nM
For compound 4 the middle estimate is 3.2-fold (0.51 log units) below the measured one; low and high end bracket the measured number.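

In this assay, replacing the 2-oxopiperidin-1-yl group with the sulfur-bearing chain on this aromatic carbon gives a 2.8-fold higher number from compound 1 to compound 4 (0.45 log units; beyond the scatter). So the position accepts a group with no ring as well as one with a six-membered ring, and the chain from compound 2 keeps activity when paired with the other end of compound 1, though the two groups are not equivalent here. The size of this step is best read against how far repeated entries for one compound can spread: the several entries of compound 2 in this assay, 14 nM; 57 nM; 9.7 nM (3 entries)

On these data alone, compound 3, bare at this position, gives > 10000 nM, which is a limit of the assay, so how much either group adds stays unknown. Also open, as far as these compounds go, is which part of the chain matters, and whether an amine, a carboxylic acid or a longer chain at this place would serve as well.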